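Para-substituent change on the shared core: nitro to fluoro

The compounds below may be only part of what the source reports. "The series", "measured", "known", "first", "only" and "open" are said of these compounds alone.

Measured compounds:
- compound 1, `O=[N+]([O-])c1ccc(-c2nnc(SCCCN3CCN(c4nc5ccccc5o4)CC3)o2)cc1`: 46900 nM
- compound 2, `Cc1ccc(-c2nnc(SCCCN3CCN(c4nc5ccccc5o4)CC3)o2)cc1`: 100000 nM

Going by the values given here, in a functional assay on A-431 cells (Homo sapiens) for inhibition, read by MTT assay, with a stated time of 72 h (on this read-out lower numbers stand for stronger inhibition and higher numbers for weaker inhibition), compound 1 gives the lowest of the two numbers; the only neighbour is compound 2, and the step of a 2.1-fold higher number from compound 1 to compound 2 (0.33 log units; beyond the scatter) is modest. Compound 3, `Fc1ccc(-c2nnc(SCCCN3CCN(c4nc5ccccc5o4)CC3)o2)cc1`, is not yet measured. Its change from compound 1 is fluoro in place of nitro on an aromatic carbon. Among the compounds with values here, the one measured step, a 2.1-fold higher number from compound 1 to compound 2 (0.33 log units; beyond the scatter), also removes the nitro, so a step of similar direction and size is expected here, likely a weaker read-out but not far beyond the scatter. Compound 3 is therefore estimated at 70000 nM (range 30000 nM to 150000 nM), an expected step of a 1.5-fold higher number from compound 1 to compound 3 (0.17 log units; within the scatter).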

Compound 3, half-maximal inhibitory concentration: 136000 nM
The estimate for compound 3 lay 1.9-fold (0.29 log units) below the measured number; the range from low to high includes it.
By their numbers in this assay, from the lowest: compound 1; then compounds 2 and 3 (each within the scatter of the next).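

Fluoro in place of nitro gives a 2.9-fold higher number from compound 1 to compound 3 (0.46 log units; beyond the scatter) and is thus a second replacement of the nitro at this position that leaves compound 1 with the lowest number. Fluoro in place of methyl gives a 1.4-fold higher number from compound 2 to compound 3 (0.13 log units; within the scatter) so these two groups are not told apart on this read-out. No available measurement accounts for the difference from the nitro compound. On these data alone, whether an amine, a carboxylic acid or a methoxy group at this position would give a number lower than that of compound 1 remains open. As far as these compounds go, whether the nitro keeps its lead with a longer chain on the shared core also remains open.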